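This account rests on a few compounds, and the source may have more. Where it says the series, first, only, none or still open, it means among the compounds named here.

Measured compounds:
compound 1 `O=C(Nc1cccc(-n2cc(-c3ccncc3)c(-c3ccc(Cl)c(O)c3)n2)c1)Nc1cccc(C(F)(F)F)c1` — in a functional assay on HT-29 cells (Homo sapiens) for inhibition, read by sulforhodamine B assay, with a stated time of 48 h (a lower number here means a stronger inhibitor of growth, a higher number a weaker inhibitor of growth), compound 1 gives > 32500 nM, a limit of the assay and not a number.
compound 2 `COc1cc(-c2nn(-c3cccc(NC(=O)Nc4ccc(Cl)c(Cl)c4)c3)cc2-c2ccncc2)ccc1Cl` — in this assay compound 2 gives 6460 nM.

Within the data shown here, compound 2 stands as the only compound of the pair with a number in this assay; the other value shown is a limit (the limit of > 32500 nM in this assay, at which 1 of the 2 values shown sits). Among the measured compounds shown here, compound 1 differs from compound 2 in more than one place, so the two values show only that compound 1 reaches no number while compound 2 does.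

Compound 3 `O=C(Nc1cccc(-n2cc(-c3ccncc3)c(-c3ccc(Cl)c(O)c3)n2)c1)Nc1ccc(Cl)c(Cl)c1` is not yet measured. It differs from compound 2 by hydrogen in place of methyl on an oxygen on an aromatic ring. For the measured compounds named here, no measured step of this kind is available in this assay. Compound 1, which also carries the hydroxy group, gives only a limit, but its other difference from compound 2 leaves the cause open. A moderate loss is expected for compound 3, a step of a 1.9-fold higher number from compound 2 to compound 3 (0.27 log units; within the scatter) from compound 2 to compound 3. The estimate for compound 3 in this assay is 12000 nM, expected to lie between 4000 nM and 36000 nM.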

Compound 3, concentration for total growth inhibition: > 32500 nM
Compound 3 was reported as a limit (the forecaster's own chance of this, stated with the estimate: 30%); middle value at least 2.7-fold (0.43 log units) away from the limit.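

Going from methoxy to hydroxy on the 4-chloro-3-methoxyphenyl group gives a readable single change in this assay: an at least 5.0-fold higher number from compound 2 to compound 3 (0.70 log units; beyond the scatter). Compound 3 gives > 32500 nM, which is a limit of the assay and not a number. The earlier pair could not tie the loss to this oxygen substituent, whereas here the methyl on the oxygen is the only difference, and the hydroxy compounds shown reach no number: the limit of > 32500 nM in this assay, at which 2 of the 3 values shown sit.

The step between 3-(trifluoromethyl)phenyl and 3,4-dichlorophenyl on the amide-type nitrogen cannot be read, since compound 1 and compound 3 both give only limits. Going by these compounds, it remains open how far the loss extends, and whether an ethoxy group or an amine in this place would keep a number in this assay.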